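The source may report more compounds than this note shows. Statements on the series, on what has been measured and on what is new or still open speak of the compounds shown alone.

Measured so far in an ADME assay on MDCK cells (Canis lupus familiaris) for permeability; on this read-out higher numbers stand for higher permeability and lower numbers for lower permeability
- compound 1 `CCS(=O)(=O)Nc1ccc(Oc2ccccc2)c(-c2cn(C)c(=O)c3[nH]ccc23)c1` gives 22 10^-6 cm/s
- compound 2 `Cn1cc(-c2cc(S(N)(=O)=O)ccc2Oc2ccccc2)c2cc[nH]c2c1=O` gives 22 10^-6 cm/s
- compound 3 `Cn1cc(-c2cc(NS(C)(=O)=O)ccc2Oc2ccccc2C(F)(F)F)c2cc[nH]c2c1=O` gives 7.8 10^-6 cm/s

Compound 1 stands level with compound 2 at the top of these three numbers, and compound 3 lies lower, beyond the scatter. The next compound to read is compound 4 `CCS(=O)(=O)Nc1ccc(OC2CCN(C)CC2)c(-c2cn(C)c(=O)c3[nH]ccc23)c1`, which differs from compound 1 as follows: 1-methylpiperidin-4-yl in place of phenyl on an oxygen on an aromatic ring.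

For the measured compounds named here, the one measured step, no change at the digits printed from compound 1 to compound 2 (within the scatter), lies at another place in the structure and says little about this change. Going by the values given here, no measured step replaces the phenyl on that oxygen. The nearest hint is compound 3 at 7.8 10^-6 cm/s, which keeps the phenoxy but carries a trifluoromethyl on it and also differs elsewhere, so it is only indirect evidence. On that weak basis a lower number is expected, with wide uncertainty. The expected step is a 3.7-fold lower number from compound 1 to compound 4 (0.56 log units; beyond the scatter). For compound 4 the estimated value is 6 10^-6 cm/s, with an expected range from 2 10^-6 cm/s to 15 10^-6 cm/s.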

Compound 4, apparent permeability: 0.55 10^-6 cm/s
Estimate against measurement, compound 4: 11-fold (1.04 log units) above; the whole stated range lies above it.
By their numbers in this assay, from the lowest: compound 4; then compound 3; then compounds 1 and 2 (each within the scatter of the next).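

In this assay, for the compounds shown here, the group on the oxygen on an aromatic ring emerges as a sensitive place: 1-methylpiperidin-4-yl in place of phenyl gives a 40-fold lower number from compound 1 to compound 4 (1.60 log units; beyond the scatter), whereas the one earlier step, at another place, gave no change at the digits printed from compound 1 to compound 2 (within the scatter). The change replaces an aromatic ring of carbon only with a non-aromatic ring holding a nitrogen, and this single step cannot separate the loss of the aromatic ring from the entry of that nitrogen. No measurement bearing on the cause of this step is available.

Cyclohexyl, tetrahydropyran-4-yl or piperidin-4-yl on the same oxygen would help to separate those two parts of the change, and the compounds shown include none of them. Also open, from the compounds shown here alone, is whether the same step holds when sulfamoyl, as in compound 2, replaces the (ethylsulfonyl)amino group.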